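Compound 4 and the limit reached by its neighbours

The source may hold more compounds than are shown below. What is called first, only, known or untested is meant among the compounds shown, and "the series" means these compounds.

In an ADME assay on BHK-21 cells (Mesocricetus auratus) for cytotoxicity, read by MTT assay, with a stated time of 72 h (a lower number here means that less compound is tolerated, a higher number that more compound is tolerated), compound 1 (`Cc1ccc(NCc2cn(-c3ccccc3)nc2-c2ccc(C(F)(F)F)cc2)cc1`) gives 88000 nM as a measured number. Compound 2 (`Cc1ccc(NCc2cn(-c3ccccc3)nc2-c2ccc(C)cc2)cc1`) reads > 100000 nM and this is a limit of the assay, not a number. Compound 3 (`Cc1ccc(NCc2cn(-c3ccccc3)nc2-c2ccccc2)cc1`) reads > 100000 nM and this too is a limit. Compound 2 thus sits at the limit of > 100000 nM in this assay, at which 2 of the 3 values shown sit, and has no number of its own.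

Compound 4 (`Cc1ccc(-c2nn(-c3ccccc3)cc2CNc2ccccc2)cc1`) differs from compound 2 by hydrogen in place of methyl on an aromatic carbon. Going by the values given here, the one measured change of this kind is a step that the two limits leave unreadable from compound 2 to compound 3 and it gives no size. The steps of an at least 1.1-fold higher number from compound 1 to compound 2 (0.05 log units; that floor lies within the scatter) and an at least 1.1-fold higher number from compound 1 to compound 3 (0.05 log units; that floor lies within the scatter) both end at a limit and show nothing beyond the scatter. Nothing measured therefore points to a real move in this assay and no direction is favoured. The expected step is a number no higher from compound 2 to compound 4 (the limit leaves the size open) and it is expected to stay within the scatter. For compound 4 the estimate is 100000 nM with an expected range from 60000 nM to 170000 nM and a reading that may well be only a limit.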

Compound 4, half-maximal cytotoxic concentration: > 100000 nM
Compound 4: no number, only a limit; the forecaster's own chance of this, stated with the estimate: 75%; the middle value lies on the limit itself.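

In this assay compound 2 and compound 4 both give a limit and not a number, so no step between them can be read: the limit of > 100000 nM in this assay, at which 3 of the 4 values shown sit.

The compounds shown leave open where compound 2, compound 3 and compound 4 truly lie, and whether hydrogen in place of methyl on an aromatic carbon changes the reading at all.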